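A few compounds are considered here, and "the series" means these few. Any claim that something is new, unique, unknown or untested is made for them only; others in the source may bear on it.

Measured compounds:
compound 1, `O=C(CSc1nc(Nc2ccccc2)c2ccccc2n1)Nc1ccccc1Br`, 10300 nM
compound 2, `O=C(CSc1nc(Nc2ccccc2)c2ccccc2n1)Nc1ccc(Cl)cc1Cl`, 8410 nM
compound 3, `C=CC(=O)Nc1cccc(NC(=O)CSc2nc(Nc3ccccc3C)c3ccccc3n2)c1`, 9920 nM

These three compounds share a core and were tested in a functional assay on NCI-H1975 cells (Homo sapiens) for inhibition, read by MTT assay, with a stated time of 72 h; a lower number here means a stronger inhibitor, a higher number a weaker inhibitor. In this assay compound 3 gives 9920 nM, and its number cannot be separated within the scatter from that of compound 1 or that of compound 2; the three values sit close together.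

Compound 4, `C=CC(=O)Nc1cccc(NC(=O)CSc2nc(Nc3cc(OC)c(OC)c(OC)c3)c3ccccc3n2)c1`, has not yet been measured in this assay. Its structure differs from compound 3 in one place: 3,4,5-trimethoxyphenyl in place of 2-methylphenyl on a nitrogen on an aromatic ring. Among the compounds with values here, the only step among the measured compounds, a 1.2-fold lower number from compound 1 to compound 2 (0.09 log units; within the scatter), concerns an exchange on an amide-type nitrogen, a different position from the one changed here, and it stayed within the scatter. Within the data shown here, no measured step touches the nitrogen on the aromatic ring, so nothing in the data points to a large move in either direction.

The expected step is therefore a 1.1-fold lower number from compound 3 to compound 4 (0.04 log units; within the scatter), with no change beyond the scatter anticipated. For compound 4 the estimated value in this assay is 9000 nM, expected to lie between 3000 nM and 30000 nM.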

Compound 4, half-maximal inhibitory concentration: > 50000 nM
Compound 4: a limit, no number; the forecaster's own chance of this, stated with the estimate: 5%; at least 5.5-fold (0.74 log units) between middle value and limit.
By their numbers in this assay, from the lowest: compounds 2, 3 and 1 (each within the scatter of the next). At a limit, above all of these: compound 4.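

In this assay, putting 3,4,5-trimethoxyphenyl in place of 2-methylphenyl on the nitrogen on an aromatic ring gives an at least 5.0-fold higher number from compound 3 to compound 4 (0.70 log units; beyond the scatter) and so makes a weaker inhibitor. This is the only step shown that lies beyond the scatter, and it shows that the group on this nitrogen can change the read-out, which the exchange on the amide-type nitrogen, with a 1.2-fold lower number from compound 1 to compound 2 (0.09 log units; within the scatter), gave no sign of. Going by these compounds, for compound 4, > 50000 nM is a limit of the assay and not a number, so the step gives a minimum size, and how far the loss really goes stays unknown.

With only two groups compared on this nitrogen while the rest of the molecule stays the same, the compounds shown cannot tell whether the loss follows from the three methoxy groups together, from one of them, or simply from a larger group. A phenyl ring carrying a single methoxy group, or one carrying an amine or a carboxylic acid, would begin to separate these possibilities.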